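The compounds below may be only part of what the source reports. "The series", "measured", "known", "first", "only" and "open" are said of these compounds alone.

Compound 1 `COc1cc(-c2nn(-c3cccc(NC(=O)Nc4cc(C(F)(F)F)cc(C(F)(F)F)c4)c3)cc2-c2ccncc2)ccc1Cl` and compound 2 `COc1cc(-c2nn(-c3cccc(NC(=O)c4cccc(C(F)(F)F)c4)c3)cc2-c2ccncc2)ccc1Cl` share the same core and differ only in the group attached to the carbonyl carbon. In a functional assay on SF-268 cells (Homo sapiens) for inhibition, read by sulforhodamine B assay, with a stated time of 48 h (a lower number here means a stronger inhibitor of growth, a higher number a weaker inhibitor of growth), compound 1 gives 978 nM, while compound 2 gives 2130 nM, the higher of the two numbers, and the gap between them lies beyond the scatter. Compound 3 `COc1cc(-c2nn(-c3cccc(NC(=O)Nc4ccc(Cl)c(C(F)(F)F)c4)c3)cc2-c2ccncc2)ccc1Cl` has not yet been measured in this assay. It differs from compound 2 by (4-chloro-3-(trifluoromethyl)phenyl)amino in place of 3-(trifluoromethyl)phenyl on a carbonyl carbon. Among the compounds with values here, no step between two measured compounds matches this change exactly, but compound 3 resembles compound 1 more closely than it resembles compound 2, and in this assay compound 1 gives 978 nM. The step from compound 2 to compound 3 is therefore expected to be a decrease of about a 2.7-fold lower number from compound 2 to compound 3 (0.43 log units; beyond the scatter), beyond the scatter. For compound 3 the estimate is 800 nM, with a range from 300 nM to 2000 nM.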

Compound 3, concentration for 50% growth inhibition: 1460 nM
Beside the measured number, compound 3's estimate is 1.8-fold (0.26 log units) below it; low and high end bracket the measured number.
By their numbers in this assay, from the lowest: compounds 1, 3 and 2 (each within the scatter of the next, the first and the last beyond it).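

In this assay putting (4-chloro-3-(trifluoromethyl)phenyl)amino in place of 3-(trifluoromethyl)phenyl on a carbonyl carbon gives a 1.5-fold lower number from compound 2 to compound 3 (0.16 log units; within the scatter) and so makes no difference that can be told from the scatter. The position thus takes a group with a new nitrogen, a hydrogen-bond donor and a chlorine, all entering at once, without a clear shift in growth inhibition. Nothing available explains why this change has so little effect.

Because the nitrogen and the chlorine enter in one step, the share of each stays unresolved. Also open, as far as these compounds go, is what a fluorine or a methyl in place of that chlorine would give, or a methylene in place of the amino nitrogen.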